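Swapping Bromo for Methoxy: Expected Plasma Half-Life

This account rests on a few compounds, and the source may have more. Where it says the series, first, only, none or still open, it means among the compounds named here.

Compound 1 `Cc1nc(N2Nc3onc(-c4ccccc4)c3C2c2ccc(Cl)cc2)sc1/N=N/c1ccc(Cl)cc1`: 7.57 h
Compound 2 `Cc1nc(N2Nc3onc(-c4ccccc4)c3C2c2ccc(Cl)cc2)sc1/N=N/c1ccc(Br)cc1`: 4.07 h

Among the compounds with values here, in an ADME assay on a cell-free system (plasma, Rattus norvegicus) for metabolic stability (on this read-out lower numbers stand for a shorter-lived compound and higher numbers for a longer-lived compound), compound 2 gives the lower of these two numbers, yet the only known step, a 1.9-fold lower number from compound 1 to compound 2 (0.27 log units; within the scatter), lies within the scatter. Compound 3 `COc1ccc(/N=N/c2sc(N3Nc4onc(-c5ccccc5)c4C3c3ccc(Cl)cc3)nc2C)cc1` differs from compound 2 by methoxy in place of bromo on an aromatic carbon. Within the data shown here, no measured pair involves a methoxy group, so the bromo-for-chloro exchange is the sole guide, and it was within the scatter. A step beyond the scatter is therefore not expected. Compound 3 is estimated at 5 h, with a range from 2 h to 12 h. The expected step is a 1.2-fold higher number from compound 2 to compound 3 (0.09 log units; within the scatter).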

Compound 3, half-life: 3.9 h
The estimate for compound 3 lay 1.3-fold (0.11 log units) above the measured number, within the range that was stated.
By their numbers in this assay, from the lowest: compounds 3, 2 and 1 (each within the scatter of the next).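

In this assay, methoxy in place of bromo gives a 1.0-fold lower number from compound 2 to compound 3 (0.02 log units; within the scatter), and methoxy in place of chloro gives a 1.9-fold lower number from compound 1 to compound 3 (0.29 log units; within the scatter). The earlier pair compared only two halogens, whereas these steps show that a 4-methoxyphenyl group, which brings an oxygen and a hydrogen-bond acceptor, cannot be told apart from either halogen-bearing ring at this place. Nothing available explains this result. From the compounds shown here alone, whether an amine or a carboxylic acid on this aromatic carbon would stand clear of the scatter remains open, as does the outcome for a longer chain such as ethoxy.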